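One chloro added to compound 1: what to expect

The source may hold more compounds than are shown below. What is called first, only, known or untested is meant among the compounds shown, and "the series" means these compounds.

Values so far in a functional assay on NCI-H460 cells (Homo sapiens) for antiproliferative activity, read by CCK-8 assay, with a stated time of 72 h; a higher number here means a weaker inhibitor, a lower number a stronger inhibitor

- compound 1 `Nc1ccccc1NC(=O)c1ccc(Cn2cnc3c(Nc4ccccc4)nc(Cl)nc32)cc1` gives 5740 nM
- compound 2 `CCCCn1cnc2c(Nc3ccccc3)nc(NCOCc3ccc(C(=O)Nc4ccccc4N)cc3)nc21` gives 8780 nM

Compound 1 stands within the usual scatter of compound 2, so these two numbers cannot be ranked. Repeated measurements of one compound could differ this much, and the two count as alike in this assay for now.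

The next compound, compound 3 `Nc1ccccc1NC(=O)c1ccc(Cn2cnc3c(Nc4cccc(Cl)c4)nc(Cl)nc32)cc1`, differs from compound 1 in one place: chloro in place of hydrogen on an aromatic carbon. This is chloro in place of hydrogen on an aromatic carbon, meta to a large group, so that phenyl becomes 3-chlorophenyl.

For the measured compounds named here, no two measured compounds differ in only one place, so no measured step shows what such a swap does, and any expectation must stay loose. The natural starting point is compound 1 (5740 nM). A small shift is expected, with a slight lean toward a stronger inhibitor but nothing expected beyond the scatter (the estimated 1.4-fold lower number from compound 1 to compound 3 (0.16 log units; within the scatter)). For compound 3 the expected value is 4000 nM (estimated range 1300 nM to 12000 nM).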

Compound 3, half-maximal inhibitory concentration: 6580 nM
Compound 3: the middle estimate sits 1.6-fold (0.22 log units) below what was measured; the measured number falls inside the stated range.
By their numbers in this assay, from the lowest: compounds 1, 3 and 2 (each within the scatter of the next).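

For the compounds shown here, this is the first step in the set that changes only one place, so it can be read directly. In this assay, replacing phenyl with 3-chlorophenyl gives a 1.1-fold higher number from compound 1 to compound 3 (0.06 log units; within the scatter) and lies within the scatter, so compound 1 and compound 3 count as alike. For this position, on an aromatic carbon meta to a large group, the result shows that adding a single chloro gives no difference that repeated measurements could separate from ordinary variation in this assay. No measurement available here bears on this result or offers a reason for it.

The compounds shown leave open whether another group on this same carbon, such as an amine, a carboxylic acid or a longer chain, would give a number clearly apart from that of compound 1. They also leave open whether chloro on a different carbon of this ring would read alike, and whether this same swap would behave the same way with other groups elsewhere on the shared core.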